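The compounds below may be only part of what the source reports. "The series", "measured", "known", "first", "only" and "open" are said of these compounds alone.

Of the compounds shown here, two sharing much of their core have been measured in an in vitro ADME assay on microsomes from liver (Rattus norvegicus) for metabolic stability, read by LC-MS, tested at 1 uM; a lower number here means slower removal, a higher number faster removal of the compound. Compound 1 `O=C(O)COc1ccc(Cl)cc1C#Cc1ccc(CO)cc1F` gives < 10 mL.min-1.g-1, which is a limit of the assay and not a number. Among the measured compounds shown here, compound 2 `Cc1ccc(S(=O)(=O)N(C)C(C)C)cc1C#Cc1cc(Cl)ccc1OCC(=O)O`, which carries an isopropyl(methyl)sulfamoyl group, gives 64 mL.min-1.g-1, the only full number obtained so far.

Compound 3 `Cc1ccc(S(=O)(=O)NC(C)C)cc1C#Cc1cc(Cl)ccc1OCC(=O)O` has not yet been measured. It differs from compound 2 by a single change, hydrogen in place of methyl on a sulfonamide nitrogen, so that isopropyl(methyl)sulfamoyl becomes isopropylsulfamoyl.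

For the measured compounds named here, no measured pair of compounds shows this change on its own, so the expectation rests only on the structural difference and on compound 2 at 64 mL.min-1.g-1. A modest fall in this assay is expected, about the size of the usual scatter, and the estimated step is a 1.8-fold lower number from compound 2 to compound 3 (0.26 log units; within the scatter). The range is kept wide, and it allows for almost no change at all. Compound 3 is expected to give about 35 mL.min-1.g-1, with an estimated range of 14 mL.min-1.g-1 to 70 mL.min-1.g-1.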

Compound 3, intrinsic clearance in microsomes: 12 mL.min-1.g-1
The estimate for compound 3 lay 2.9-fold (0.46 log units) above the measured number; measured number outside the range, below it.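

Hydrogen in place of methyl on the sulfonamide nitrogen gives a 5.3-fold lower number from compound 2 to compound 3 (0.73 log units; beyond the scatter) in this assay, so a change of one carbon at this position is enough to move the number beyond the scatter. Among the compounds shown here, compounds 1 and 2 formed no pair differing in one place, and they could not tie any part of the number of compound 2 to the isopropyl(methyl)sulfamoyl group; compound 3 now ties part of it to the methyl on that nitrogen. With isopropylsulfamoyl in place, little room may remain for reading any further fall in this read-out, as compound 1 stands at a limit of the assay and not at a number: the limit of < 10 mL.min-1.g-1 in this assay, at which 1 of the 3 values shown sits.

The compounds shown leave open whether the isopropyl group on the same nitrogen also bears on the number, and how an ethyl group or a cyclopropyl group would read if it took the place of the methyl or of the isopropyl. This single pair also cannot tell whether the same step would appear with a different group on the other side of the shared core.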